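Moving the hydroxy group onto the saturated-carbon aryl ring

This account rests on a few compounds, and the source may have more. Where it says the series, first, only, none or still open, it means among the compounds named here.

Measured compounds:
compound 1, `CC(C)(C)C1=NN(c2ccc(F)cc2)C(c2ccc(O)cc2)C1`, 95.5%
compound 2, `CC(C)(C)C1=NN(c2ccc(Cl)cc2)C(c2ccc(Cl)cc2)C1`, 11.8%
compound 3, `CC(C)(C)C1=NN(c2ccc(O)cc2)C(c2ccc(Cl)cc2)C1`, 72.2%

In an assay on isolated protein for inhibition of protein kinase C zeta type (Homo sapiens), with a stated time of 4 min, tested at 62.5 uM (a higher number here means more inhibition at the concentration tested (going by the name of the read-out), a lower number less inhibition), compound 2 gives 11.8%, the lowest of the three numbers; compound 3 sits a number 60.4 percentage points higher from compound 2 to compound 3 (beyond the scatter), and compound 1, which carries a hydroxyphenyl on the saturated ring carbon, gives 95.5%. The unmeasured compound 4, `CC(C)(C)C1=NN(c2ccc(Cl)cc2)C(c2ccc(O)c(F)c2)C1`, differs from compound 2 in one place: 3-fluoro-4-hydroxyphenyl in place of 4-chlorophenyl on a saturated ring carbon. Going by the values given here, the one measured step that bears on it is a number 60.4 percentage points higher from compound 2 to compound 3 (beyond the scatter), where a hydroxy on an aromatic carbon replaced a chloro; it was large and upward. Among the compounds with values here, compound 4 brings in a hydroxy-bearing ring as well, on the saturated ring carbon rather than on the ring nitrogen, together with a fluoro, so no measured step matches it exactly. A large rise in this assay is nonetheless expected, with the estimated step of a number 63.2 percentage points higher from compound 2 to compound 4 (beyond the scatter). Compound 4 is therefore estimated at 75%, within a range from 50% to 95%.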

Compound 4, a percentage reported as inhibition, at one concentration (the size of the read-out at that concentration, not a potency): 98.5%
Estimate against measurement, compound 4: 23.5 percentage points below; the measured number lies above the stated range.
By their numbers in this assay, from the lowest: compound 2; then compound 3; then compounds 1 and 4 (each within the scatter of the next).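

In this assay, the change at the saturated ring carbon gives a number 86.7 percentage points higher from compound 2 to compound 4 (beyond the scatter), with the 4-chlorophenyl group on the other side of the core left in place. Going by these compounds alone, until now, the only one-place step was the swap of chloro for hydroxy on the aryl ring of compound 2 that gave compound 3; this result shows that a single change at the saturated ring carbon can also move the number far beyond the scatter. Nothing shown explains why the number rises so much.

The new group brings a hydroxy and a fluoro together, so the compounds shown do not separate what each contributes. As far as these compounds go, how an amine or a carboxylic acid in place of that hydroxy would read out at this position also remains open.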